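Adding a nitro group to compound 3: working notes

A few compounds are considered here, and "the series" means these few. Any claim that something is new, unique, unknown or untested is made for them only; others in the source may bear on it.

Compound 1 `COc1ccc(-c2c[nH]c(=O)n2-c2cc(OC)c(OC)c(OC)c2)cc1[N+](=O)[O-]`: > 50000 nM (a limit)
Compound 2 `COc1cc(-n2c(-c3ccc(Br)cc3)cn(C(C)=O)c2=O)cc(OC)c1OC`: 1300 nM
Compound 3 `COc1ccc(-c2cn(C(C)=O)c(=O)n2-c2cc(OC)c(OC)c(OC)c2)cc1`: 17800 nM

All readings come from a functional assay on A549 cells (Homo sapiens) for cytotoxicity, read by MTT assay, with a stated time of 48 h; a higher number here means a weaker inhibitor, a lower number a stronger inhibitor. Going by the values given here, compound 3 has the higher of the two actual numbers, and compound 2 is its only numerical neighbour. Compound 1 is the remaining entry, and its reading is a limit rather than a number: the limit of > 50000 nM in this assay, at which 1 of the 3 values shown sits.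

The next step leads to compound 4 `COc1ccc(-c2cn(C(C)=O)c(=O)n2-c2cc(OC)c(OC)c(OC)c2)cc1[N+](=O)[O-]`, which is still unmeasured. The change is nitro in place of hydrogen on an aromatic carbon, ortho to a methoxy group and meta to a large group. Among the compounds with values here, the only measured step is a 14-fold higher number from compound 2 to compound 3 (1.14 log units; beyond the scatter). It is large, but it is methoxy in place of bromo, a different change, so it shows only that a single substitution can matter in this series. Within the data shown here, no measured step isolates nitro. Starting from compound 3 at 17800 nM, no clear shift in this assay is expected, and the direction remains uncertain. The expected change is a 1.3-fold lower number from compound 3 to compound 4 (0.10 log units; within the scatter), an estimate that stays within the scatter. Compound 4 is expected at 14000 nM, with an estimated range of 3500 nM to 50000 nM.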

Compound 4, half-maximal inhibitory concentration: 40900 nM
Beside the measured number, compound 4's estimate is 2.9-fold (0.47 log units) below it; the range from low to high includes it.
By their numbers in this assay, from the lowest: compound 2; then compound 3; then compound 4. At a limit, above all of these: compound 1.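

In this assay, going by these compounds alone, nitro on the aromatic carbon ortho to a methoxy group and meta to a large group gives a 2.3-fold higher number from compound 3 to compound 4 (0.36 log units; beyond the scatter), the first measured step that isolates this change and a modest one beyond the scatter. Acetyl in place of hydrogen on the aromatic nitrogen gives an at least 1.2-fold lower number from compound 1 to compound 4 (0.08 log units; that floor lies within the scatter), so with nitro present no gain from the acetyl group can be read. The reading of compound 1 is a limit, which leaves that step with only a floor: the limit of > 50000 nM in this assay, at which 1 of the 4 values shown sits.

Open, on these data alone, is whether an amine or a carboxylic acid on the same aromatic carbon would shift the number in the same direction as nitro. Also open, as far as these compounds go, is whether nitro gives a similar step when bromo replaces the methoxy group, as in compound 2.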